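A few compounds are considered here, and "the series" means these few. Any claim that something is new, unique, unknown or untested is made for them only; others in the source may bear on it.

Compound 1 `CC(Sc1nnc(-c2ccncc2)s1)C(=O)Nc1ccccc1` and compound 2 `CC(Sc1nnc(-c2ccncc2)s1)C(=O)NCc1ccc(Cl)cc1` share the same core and differ only in the amide portion. In an ADME assay on BHK-21 cells (Mesocricetus auratus) for cytotoxicity, with a stated time of 3 days (on this read-out higher numbers stand for lower toxicity in this test and lower numbers for higher toxicity in this test), compound 1 gives > 50000 nM, a value that is a limit of the assay and not a measured number. In this assay compound 2 is recorded as "not determined" (no result reported), so compound 2 stands without a number in this assay. Among the values shown, the only point of reference is the limit of > 50000 nM in this assay, at which 1 of the 2 values shown sits. Compound 3 `O=C(CSc1nnc(-c2ccncc2)s1)NCc1ccc(Cl)cc1` differs from compound 2 by hydrogen in place of methyl on a saturated chain carbon bound to a carbonyl carbon and a sulfur, a small change on the chain linking the sulfur to the amide. Among the measured compounds shown here, no step between measured compounds is available for this change, and the single known value is a limit, so no shift beyond the usual scatter in this assay is expected in either direction. Compound 3 is therefore expected to give about 50000 nM, with a range from 15000 nM to 100000 nM, and most likely again only a limit.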

Compound 3, half-maximal cytotoxic concentration: > 50000 nM
Compound 3 gave a limit, no number; the forecaster's own chance of this, stated with the estimate: 80%; the middle value lies on the limit itself.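

Compound 2 stands without a number in this assay and compound 3 gives only a limit, so no step can be read between them. The compounds shown leave open whether hydrogen in place of methyl on that chain carbon changes the result in this assay at all.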